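Aryloxymethyl ketone series: trifluoromethyl variant of compound 2

The source may hold more compounds than are shown below. What is called first, only, known or untested is meant among the compounds shown, and "the series" means these compounds.

Compound 1 `CC(C)[C@H](NC(=O)COc1cccc2ccccc12)C(=O)N[C@@H](CC(=O)O)C(=O)COc1cc(C(F)(F)F)cc(C(F)(F)F)c1` carries a bis(trifluoromethyl)phenoxy group. In a functional assay on Jurkat cells (Homo sapiens) (on this read-out lower numbers stand for stronger inhibition and higher numbers for weaker inhibition), compound 1 gives only a limit, > 100000 nM. Compound 2 `CC(C)[C@H](NC(=O)COc1cccc2ccccc12)C(=O)N[C@@H](CC(=O)O)C(=O)COc1cccc(F)c1` gives only a limit in this assay as well, > 100000 nM. Going by the values given here, both values thus sit at the limit of > 100000 nM in this assay, at which 2 of the 2 values shown sit, so no step between measured compounds is known. Compound 3 `CC(C)[C@H](NC(=O)COc1cccc2ccccc12)C(=O)N[C@@H](CC(=O)O)C(=O)COc1cccc(C(F)(F)F)c1F` differs from compound 2 in one place: 2-fluoro-3-(trifluoromethyl)phenyl in place of 3-fluorophenyl on an oxygen on a saturated carbon. Among the compounds with values here, with no measured step to lean on, the expected step from compound 2 to compound 3 is a number no higher from compound 2 to compound 3 (the limit leaves the size open), none beyond the scatter. Compound 3 is therefore estimated at 100000 nM in this assay, between 30000 nM and 300000 nM, most likely again reported only as a limit.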

Compound 3, half-maximal inhibitory concentration: 50400 nM
Estimate against measurement, compound 3: 2.0-fold (0.30 log units) above; measured number inside the range.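

In this assay, going by these compounds alone, compound 3 gives 50400 nM, the first value at this position that is a number rather than a limit. Replacing 3-fluorophenyl with 2-fluoro-3-(trifluoromethyl)phenyl on this oxygen gives an at least 1.9-fold lower number from compound 2 to compound 3 (0.29 log units; that floor lies within the scatter), so the true size of the step stays unresolved. The comparison starts from a limit: the limit of > 100000 nM in this assay, at which 2 of the 3 values shown sit.

Open, as far as these compounds go, is whether the fluoro or the trifluoromethyl group of the entering substituent accounts for the measurable value. Also open, from the compounds shown here alone, is how an amine or a carboxylic acid on this phenyl ring would read in this assay.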